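The source may hold more compounds than are shown below. What is called first, only, known or untested is meant among the compounds shown, and "the series" means these compounds.

Measured so far in an assay on isolated protein for inhibition of malate dehydrogenase, mitochondrial (Sus scrofa), with stated times of 45 min and 30 min; a higher number here means a weaker inhibitor, a lower number a stronger inhibitor:
compound 1, `O=S(=O)(Nc1ccc(-c2nc3ccccc3o2)cc1)c1cccc(O)c1`: > 63000 nM
compound 2, `O=S(=O)(Nc1ccc2oc(-c3ccccc3)nc2c1)c1ccc(Cl)cc1`: > 63000 nM
compound 3, `COc1ccccc1S(=O)(=O)Nc1ccc2oc(-c3ccccc3)nc2c1`: > 63000 nM

Each of these three readings is a limit of the assay and not a number. Compound 1 gives only a limit, > 63000 nM. Compound 2 likewise gives only a limit, > 63000 nM. Compound 3 too gives only a limit, > 63000 nM. Among the compounds with values here, the whole series so far stands at one point, namely (the limit of > 63000 nM in this assay, at which 3 of the 3 values shown sit). Within the data shown here, the only step between two measured compounds that differ in one place, a step that the two limits leave unreadable from compound 2 to compound 3, cannot be read, since both of its ends are limits; it gives no sense of how a change on the sulfonyl sulfur moves the read-out.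

Compound 4, `COc1ccc(S(=O)(=O)Nc2ccc(-c3nc4ccccc4o3)cc2)cc1`, is not yet measured. It differs from compound 1 in one place: 4-methoxyphenyl in place of 3-hydroxyphenyl on a sulfonyl sulfur. Among the measured compounds shown here, no measured step bears on this change in a readable way, so the expectation rests on where compound 1 stands. The implied step in this assay, a step that the limit leaves unreadable from compound 1 to compound 4, is expected to be of no readable size in either direction. Compound 4 is therefore expected to sit at about 100000 nM, with a range from 30000 nM to 400000 nM, and most probably to be reported again as a limit.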

Compound 4, half-maximal inhibitory concentration: > 63000 nM
Compound 4: no number, only a limit; the forecaster's own chance of this, stated with the estimate: 85%; the middle value does not contradict the limit.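

In this assay compound 4 gives > 63000 nM, again a limit and not a number, so no readable step links compound 1 and compound 4, whose values are both limits. The compounds shown leave open whether any change on the sulfonyl sulfur would bring a readable value in this assay, since the series still stands at one point: the limit of > 63000 nM in this assay, at which 4 of the 4 values shown sit.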